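The compounds below may be only part of what the source reports. "The series", "measured", "known", "first", "only" and "open" are said of these compounds alone.

Compound 1 `COC(=O)c1ccc(NCc2cncn2Cc2ccc(C#N)cc2)cc1-c1ccccc1`: > 10000 nM
Compound 2 `Clc1ccc(Cn2cncc2CNc2cccc(-c3ccccc3)c2)cc1`: 10000 nM

Both values come from a toxicity assay on NIH3T3 cells (Mus musculus) for cytotoxicity, read by resazurin assay; a higher number here means that more compound is needed for the effect, a lower number that less compound is needed. Compound 1 stands at the limit of > 10000 nM in this assay, at which 1 of the 2 values shown sits, which is a limit of the assay rather than a measured number. Compound 2 gives 10000 nM in this assay, so neither compound shows marked cytotoxicity on these mouse fibroblast cells, and the two numbers cannot be ranked against each other.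

Compound 3 `COC(=O)c1ccc(NCc2cncn2Cc2ccc(Br)cc2)cc1-c1ccccc1` has not yet been measured. It differs from compound 1 in a single place: bromo in place of cyano on an aromatic carbon. The rest of the molecule, including the ester and the phenyl group on the shared core, stays the same.

Among the measured compounds shown here, no pair of measured compounds differing in one place is available, so the change is judged on its own. The step of a number no higher from compound 1 to compound 3 (the limit leaves the size open) is expected to stay within the usual scatter, in no particular direction. Compound 3 is therefore estimated at about 10000 nM, between 4000 nM and 30000 nM, with a fair chance that the assay again reports only a limit.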

Compound 3, half-maximal effective concentration: > 10000 nM
Compound 3 gave a limit, no number; the forecaster's own chance of this, stated with the estimate: 60%; the middle value lies on the limit itself.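

Compound 1 and compound 3 both give only a limit rather than a number, so no step can be read for bromo in place of cyano: the limit of > 10000 nM in this assay, at which 2 of the 3 values shown sit.

The compounds shown leave open whether this swap changes the amount of compound needed for cytotoxicity at all.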